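The source may hold more compounds than are shown below. What is called first, only, known or untested is meant among the compounds shown, and "the series" means these compounds.

Compound 3 `CCCCCN(CCCCC)C(=O)Cc1c(-c2ccc(OC)cc2)nn2c(CC)cc(CC)nc12` gives 2.17 nM in an assay on C6 cells for displacement of a labelled ligand from Translocator protein (Rattus norvegicus), read by scintillation counting, with a stated time of 2 h (a lower number here means a stronger inhibitor, a higher number a weaker inhibitor), the lowest of the three numbers measured. Its nearest neighbour is compound 2 `CCCN(CCC)C(=O)Cc1c(-c2ccc(OC)cc2)nn2c(CC)cc(CC)nc12`, which gives 5.57 nM in this assay; the furthest is compound 1 `CCc1cc(CC)n2nc(-c3ccc(OC)cc3)c(CC(=O)N(C)C)c2n1`, which gives 37.6 nM. Across these three compounds, which share one core and differ only in the group on the carbonyl carbon, a larger dialkylamino group has gone with a lower number each time: a 6.8-fold lower number from compound 1 to compound 2 (0.83 log units; beyond the scatter), a 17-fold lower number from compound 1 to compound 3 (1.24 log units; beyond the scatter) and a 2.6-fold lower number from compound 2 to compound 3 (0.41 log units; beyond the scatter).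

Compound 4 `CCc1cc(CC)n2nc(-c3ccc(OC)cc3)c(CC(=O)N(CC)C(C)(C)C)c2n1` has not yet been measured. It differs from compound 3 by a group of 7 heavy atoms (6 carbon, 1 nitrogen; no ring) in place of a group of 11 heavy atoms (10 carbon, 1 nitrogen; no ring), on a carbonyl carbon, so the change runs the other way, towards a smaller group, though a branched one unlike any in the measured set. The steps from compound 1 to compound 2 and from compound 2 to compound 3 bear on it most directly, and both place the change in the direction of a higher number. Compound 4 is therefore expected to give a modestly higher number than compound 3, with a 3.7-fold higher number from compound 3 to compound 4 (0.57 log units; beyond the scatter) the estimated step. For compound 4 the estimate in this assay is 8 nM, within a range from 3 nM to 25 nM.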

Compound 4, inhibition constant: 59.1 nM
Compound 4: middle estimate off by 7.4-fold (0.87 log units), on the low side; measured number above the stated range.
By their numbers in this assay, from the lowest: compound 3; then compound 2; then compounds 1 and 4 (each within the scatter of the next).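

The group on the carbonyl carbon in compound 4 has the same heavy-atom count as dipropylamino, yet in this assay the change gives an 11-fold higher number from compound 2 to compound 4 (1.03 log units; beyond the scatter), so the count alone does not set the number at this position. Against dipentylamino the same group gives a 27-fold higher number from compound 3 to compound 4 (1.44 log units; beyond the scatter), while against dimethylamino it gives a 1.6-fold higher number from compound 1 to compound 4 (0.20 log units; within the scatter), so compound 4 goes against the trend of lower numbers with larger groups seen across compounds 1, 2 and 3. No measurement shown here bears on the reason for this result.

The compounds shown leave open whether branching in general or the tert-butyl group in particular goes with the higher number, which a diisopropylamino group would help to separate. They also leave open whether a longer chain, such as dihexylamino, would continue the trend.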